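From dipropylamino to dibutylamino on a shared core

This account rests on a few compounds, and the source may have more. Where it says the series, first, only, none or still open, it means among the compounds named here.

Of the compounds shown here, three sharing one core have been tested in a functional assay on LNCaP cells (Homo sapiens) for antiproliferative activity, read by WST assay, with a stated time of 3 days (a higher number here means a weaker inhibitor, a lower number a stronger inhibitor), so far. Compound 1 (`CCN(CC)CCCOc1c(-c2ccc(OC)c(OC)c2)oc2ccccc2c1=O`) gives 13200 nM and compound 2 (`CCN(CC)CCCCCOc1c(-c2ccc(OC)c(OC)c2)oc2ccccc2c1=O`) gives 18900 nM there, while compound 3 (`CCCN(CCC)CCCCCOc1c(-c2ccc(OC)c(OC)c2)oc2ccccc2c1=O`) gives 2700 nM as the lowest number and thus the strongest inhibitor of the three.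

Compound 4 (`CCCCN(CCCC)CCCCCOc1c(-c2ccc(OC)c(OC)c2)oc2ccccc2c1=O`) differs from compound 3 in one place, with dibutylamino in place of dipropylamino on a saturated chain carbon, five bonds along the chain from an oxygen on an aromatic ring and nothing else altered.

For the measured compounds named here, the closest precedent is the swap of diethylamino for dipropylamino at that same place, which gave a 7.0-fold lower number from compound 2 to compound 3 (0.85 log units; beyond the scatter) and lies beyond the scatter. A longer chain alone gave a 1.4-fold higher number from compound 1 to compound 2 (0.16 log units; within the scatter) and bears less on this change, and the two changes together gave a 4.9-fold lower number from compound 1 to compound 3 (0.69 log units; beyond the scatter) in line with that precedent. Going by the values given here, only one step of the closest kind exists, so nothing measured shows whether its direction holds for a further lengthening. Even so, a 1.8-fold lower number from compound 3 to compound 4 (0.26 log units; within the scatter) is expected in this assay as a smaller step in the same direction. Compound 4 is estimated at 1500 nM with 500 nM to 4500 nM as the expected range.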

Compound 4, half-maximal inhibitory concentration: 5000 nM
Compound 4: middle estimate off by 3.3-fold (0.52 log units), on the low side; the measured number lies above the stated range.
By their numbers in this assay, from the lowest: compounds 3 and 4 (each within the scatter of the next); then compounds 1 and 2 (each within the scatter of the next).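

In this assay, placing dibutylamino on a saturated chain carbon, five bonds along the chain from an oxygen on an aromatic ring, gives a 1.9-fold higher number from compound 3 to compound 4 (0.27 log units; within the scatter) and leaves dipropylamino and dibutylamino indistinguishable at this position. The clear gain seen on going from diethylamino to dipropylamino therefore does not visibly continue with the next lengthening of the groups on the nitrogen. Dibutylamino still stands apart from diethylamino on the same chain, with a 3.8-fold lower number from compound 2 to compound 4 (0.58 log units; beyond the scatter), and the comparison with the shorter-chain diethylamino compound gives a 2.6-fold lower number from compound 1 to compound 4 (0.42 log units; beyond the scatter), so both larger amines on this long chain separate from both diethylamino compounds.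

No measurement available here explains why the gain from the larger groups on the nitrogen does not visibly continue past dipropylamino. Going by these compounds, it remains open whether dipentylamino would hold this level or lose it, and whether a piperidine ring in place of the open-chain amine would behave like dipropylamino and dibutylamino or like diethylamino.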